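Swapping bromo for chloro on a shared core

The source may report more compounds than this note shows. Statements on the series, on what has been measured and on what is new or still open speak of the compounds shown alone.

In a functional assay on THP-1 cells (Homo sapiens) for inhibition, read by sulforhodamine B assay, with a stated time of 48 h, tested at 50 uM (a lower number here means less inhibition of growth, a higher number more inhibition of growth at the concentration tested), the measured compounds gave these values:

Compound 1, `O=C1C(=O)N(CCCCCn2cc(COc3cc(=O)oc4ccccc34)nn2)c2ccc(Cl)cc21`: 59%
Compound 2, `O=C1C(=O)N(CCCCCn2cc(COc3cc(=O)oc4ccccc34)nn2)c2ccc(Br)cc21`: 52%
Compound 3, `O=C1C(=O)N(CCCn2cc(COc3cc(=O)oc4ccccc34)nn2)c2ccc(Br)cc21`: 72%

Compound 3 stands highest of the three; its values against compound 1 and compound 2 lie beyond the scatter. The difference between the core of compound 3 and the core of compound 2 is not broken down here. One change is seen directly: chloro in place of bromo on an aromatic carbon gave a number 7 percentage points higher from compound 2 to compound 1 (within the scatter).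

Compound 4, `O=C1C(=O)N(CCCn2cc(COc3cc(=O)oc4ccccc34)nn2)c2ccc(Cl)cc21`, is not yet measured. It differs from compound 3 by chloro in place of bromo on an aromatic carbon, the same change as that from compound 2 to compound 1. A step of about the same size is expected, a number 4 percentage points higher from compound 3 to compound 4 (within the scatter), resting on the earlier step of a number 7 percentage points higher from compound 2 to compound 1 (within the scatter). Compound 4 is therefore estimated at 76%, likely between 62% and 88%.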

Compound 4, percent growth inhibition at one concentration: 78%
For compound 4 the middle estimate is 2 percentage points below the measured one, within the range that was stated.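

In this assay, chloro in place of bromo on an aromatic carbon gave a number 6 percentage points higher from compound 3 to compound 4 (within the scatter). Set beside the earlier case, the same swap gave much the same result on both cores: the same change on two cores in this assay, a number 7 percentage points higher (within the scatter) from compound 2 to compound 1 and a number 6 percentage points higher (within the scatter) from compound 3 to compound 4, 1 percentage points apart, within the scatter of two such steps Both steps lie within the scatter, so the data show only that the swap carries across these two cores without a visible difference in outcome; they do not show that chloro truly outperforms bromo, nor that the same would hold on any other core.

The compounds shown carry only chloro or bromo at this place on the ring. Going by these compounds, what fluoro, methoxy or an amine would give there remains open.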